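Removing the aryl methyl from compound 2

A few compounds are considered here, and "the series" means these few. Any claim that something is new, unique, unknown or untested is made for them only; others in the source may bear on it.

Measured in a functional assay on A549 cells (Homo sapiens) for antiproliferative activity, read by sulforhodamine B assay, with a stated time of 48 h; on this read-out lower numbers stand for stronger inhibition and higher numbers for weaker inhibition:
- compound 1 `COc1cc(OC)c2sc(-c3ccc(N/C=C\C(=O)c4ccc(OC)c(O)c4)c(C)c3)nc2c1` gives 14300 nM
- compound 2 `COc1ccc2nc(-c3ccc(N/C=C\C(=O)c4cc(OC)c(OC)c(OC)c4)c(C)c3)sc2c1` gives 11100 nM
- compound 3 `COc1ccc2nc(-c3ccc(N/C=C\C(=O)c4ccc(OC)c(F)c4)c(C)c3)sc2c1` gives 1400 nM

Compound 2 at 11100 nM lies within the scatter of compound 1 at 14300 nM. Compound 3 gives 1400 nM, a lower number than compound 2 and beyond the scatter from it.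

Compound 4 `COc1ccc2nc(-c3ccc(N/C=C\C(=O)c4cc(OC)c(OC)c(OC)c4)cc3)sc2c1` is the next case. It has hydrogen in place of methyl on an aromatic carbon of compound 2: hydrogen in place of methyl on an aromatic carbon. Among the measured compounds shown here, all three measured compounds carry this methyl, so no measured pair shows what its loss does. Compounds 1, 2 and 3 also differ from one another elsewhere. The change itself is small, so in this assay no step beyond the scatter is expected, and no direction can be argued from these data. The estimated change is a 1.2-fold lower number from compound 2 to compound 4 (0.09 log units; within the scatter). For compound 4 the expected value is 9000 nM, with an estimated range of 3000 nM to 25000 nM.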

Compound 4, half-maximal inhibitory concentration: 12100 nM
Estimate against measurement, compound 4: 1.3-fold (0.13 log units) below, and the stated range covers the measured number.
By their numbers in this assay, from the lowest: compound 3; then compounds 2, 4 and 1 (each within the scatter of the next).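

Within this assay, replacing the methyl with hydrogen on this aromatic carbon, ortho to a large group, gives a 1.1-fold higher number from compound 2 to compound 4 (0.04 log units; within the scatter), the first direct reading of this position, since compounds 1, 2 and 3 all carry the methyl. Methyl and hydrogen are therefore not told apart here, and on the background of compound 2 the methyl is not required for the level of activity seen. No measurement on hand bears on why the two compounds read alike.

On these data alone, whether the methyl is equally dispensable on the background of compound 3, at 1400 nM, remains open, as this pair covers only one background. Also open, as far as these compounds go, is how a larger or different group on the same carbon would read, such as an ethyl, a methoxy or an amine.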